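A Bromine in Place of Two Fluorines on the Aryl Ether

The source may hold more compounds than are shown below. What is called first, only, known or untested is meant among the compounds shown, and "the series" means these compounds.

Among the compounds with values here, compound 1 `Cc1nn(C)c(Oc2cccc(F)c2)c1/C=N\CCCCCOc1cc2oc(=O)cc(C)c2cc1Cl` is the only member of this small set with a full number: in a functional assay on HepG2 cells (Homo sapiens) for antiproliferative activity, read by MTT assay, with a stated time of 72 h (a lower number here means a stronger inhibitor, a higher number a weaker inhibitor), compound 1 gives 13400 nM. Compound 2 `Cc1nn(C)c(Oc2ccccc2F)c1/C=N\CCCCCCOc1cc2oc(=O)cc(C)c2cc1Cl` reaches only the limit of this assay, where compound 2 gives > 25000 nM. Compound 3 `Cc1nn(C)c(Oc2cccc(F)c2F)c1/C=N\CCCCCCOc1cc2oc(=O)cc(C)c2cc1Cl` likewise reaches only a limit in this assay, where compound 3 gives > 25000 nM. The step that the two limits leave unreadable from compound 2 to compound 3 has no readable size because the limit of > 25000 nM in this assay, at which 2 of the 3 values shown sit, hides both of its ends. Compound 3 thus stands at the limit itself, with one further value sitting there as well, and only compound 1 lies within the readable range.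

Compound 4 `Cc1nn(C)c(Oc2ccccc2Br)c1/C=N\CCCCCCOc1cc2oc(=O)cc(C)c2cc1Cl` differs from compound 3 by 2-bromophenyl in place of 2,3-difluorophenyl on an oxygen on an aromatic ring. Within the data shown here, no measured step bears directly on this change, and the one single-point step in the set is unreadable. The expected step of a number no higher from compound 3 to compound 4 (the limit leaves the size open) is therefore set near zero. Compound 4 is accordingly estimated to give 25000 nM in this assay, between 8000 nM and 60000 nM, most probably again only as a limit.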

Compound 4, half-maximal inhibitory concentration: 24200 nM
For compound 4 the middle estimate is 1.0-fold (0.01 log units) above the measured one, within the range that was stated.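

In this assay, 2-bromophenyl in place of 2,3-difluorophenyl on an oxygen on an aromatic ring gives an at least 1.0-fold lower number from compound 3 to compound 4 (0.01 log units; that floor lies within the scatter), and bromo in place of fluoro on an aromatic carbon gives an at least 1.0-fold lower number from compound 2 to compound 4 (0.01 log units; that floor lies within the scatter). Unlike compounds 2 and 3, compound 4 gives a full number, so this position now has one readable value among otherwise matching compounds, although that value offers no evidence of a real gain in potency. The true size of both steps stays open because compounds 2 and 3 each give only a limit: the limit of > 25000 nM in this assay, at which 2 of the 4 values shown sit.

Going by these compounds, whether a chlorine, a methoxy group or an amine on the aryl ring in place of the bromine would lower the number remains open. So does the effect of the 2-bromophenyl group when paired with the chain of compound 1.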